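Aryl hydrazone variation in the adenosine series

The source may hold more compounds than are shown below. What is called first, only, known or untested is meant among the compounds shown, and "the series" means these compounds.

Measured so far:
compound 1 `Nc1nc(N/N=C/c2ccc3ncccc3c2)nc2c1ncn2[C@@H]1O[C@H](CO)[C@@H](O)[C@H]1O`: 9.8 nM
compound 2 `CCCCc1nc(/C=N/Nc2nc(N)c3ncn([C@@H]4O[C@H](CO)[C@@H](O)[C@H]4O)c3n2)c(Cl)[nH]1`: 12 nM
compound 3 `Nc1nc(N/N=C/c2ccc(N(c3ccccc3)c3ccccc3)cc2)nc2c1ncn2[C@@H]1O[C@H](CO)[C@@H](O)[C@H]1O`: a limit, > 10000 nM

In an assay on CHO-K1 cells for displacement of a labelled ligand from adenosine receptor A1 (Homo sapiens), read by scintillation counting, with a stated time of 60 min (a higher number here means a weaker inhibitor, a lower number a stronger inhibitor), compound 1 gives 9.8 nM and compound 2 gives 12 nM. Among the measured compounds shown here, the one single-place step measured is a 1.2-fold higher number from compound 1 to compound 2 (0.09 log units; within the scatter). Compound 2 thus holds the highest of the two numbers, with compound 1 nearest and within the scatter. Compound 3 reaches only a limit, > 10000 nM; (the limit of > 10000 nM in this assay, at which 1 of the 3 values shown sits).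

Compound 4 `Nc1nc(N/N=C/c2ccc(Cl)c(C(F)(F)F)c2)nc2c1ncn2[C@@H]1O[C@H](CO)[C@@H](O)[C@H]1O` differs from compound 2 by 4-chloro-3-(trifluoromethyl)phenyl in place of 2-butyl-5-chloro-1H-imidazol-4-yl on a carbon with a double bond to nitrogen. Only a 1.2-fold higher number from compound 1 to compound 2 (0.09 log units; within the scatter) bears on this change, and it was flat; compound 3 shows that not every aryl group keeps measurable binding. A moderate loss is therefore expected, a 5.0-fold higher number from compound 2 to compound 4 (0.70 log units; beyond the scatter). Compound 4 is estimated at 60 nM, in the range 10 nM to 600 nM.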

Compound 4, inhibition constant: > 10000 nM
Compound 4: only a limit was reported; the forecaster's own chance of this, stated with the estimate: 10%; middle value at least 160-fold (2.22 log units) from the limit.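

In this assay compound 4 gives > 10000 nM, which is a limit. The steps of an at least 830-fold higher number from compound 2 to compound 4 (2.92 log units; beyond the scatter) and an at least 1000-fold higher number from compound 1 to compound 4 (3.00 log units; beyond the scatter) show that this place on the carbon with a double bond to nitrogen does not accept every aryl group: 4-chloro-3-(trifluoromethyl)phenyl does not keep the binding seen with quinolin-6-yl and 2-butyl-5-chloro-1H-imidazol-4-yl. Loss of measurable binding is therefore not confined to compound 3: the limit of > 10000 nM in this assay, at which 2 of the 4 values shown sit.

As far as these compounds go, it remains open whether the loss follows the chlorine, the trifluoromethyl or the absence of ring nitrogen. An unsubstituted phenyl or a pyridin-3-yl at this place would help separate these.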